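The source may report more compounds than this note shows. Statements on the series, on what has been measured and on what is new or still open speak of the compounds shown alone.

Compound 1 `CC#C[C@H]1CN(S(=O)(=O)c2ccc(N)nc2)CCN1c1ccc(S(=O)(=O)NC)cn1` gives 381 nM in an assay on cells (Hepatocyte) for inhibition of glucokinase regulatory protein (Mus musculus), with stated times of 20 min and 40 min; a higher number here means that more compound is needed for the effect, a lower number that less compound is needed.
Compound 2 `CC#C[C@H]1CN(S(=O)(=O)c2ccc(N)nc2)CCN1c1ccc(S(N)(=O)=O)cc1` gives 37 nM in this assay.
Compound 3 `CC#C[C@H]1CN(S(=O)(=O)c2ccc(N)nc2)CCN1c1ccc(C(C)(O)C(F)(F)F)nc1` gives 1450 nM in this assay.

Among these three, compound 2 stands at the lowest number in this assay; the numbers for compound 1 and compound 3 both lie higher, and in each case the gap is beyond the usual scatter.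

Compound 4 `CC#C[C@H]1CN(S(=O)(=O)c2ccc(N)nc2)CCN1c1ccc(S(C)(=N)=O)cc1` differs from compound 2 in one place: a group of 4 heavy atoms (1 carbon, 1 nitrogen, 1 oxygen, 1 sulfur; no ring) in place of a group of 4 heavy atoms (1 nitrogen, 2 oxygen, 1 sulfur; no ring), on an aromatic carbon. Among the compounds with values here, no measured pair shows this exchange, so there is nothing to lean on except the closeness of the two groups in size and in counted donors and acceptors. In this assay the step is expected to be small, in either direction, and likely not beyond the scatter.

Compound 4 is therefore estimated at 55 nM, with a range from 18 nM to 170 nM. That estimate means an expected step of a 1.5-fold higher number from compound 2 to compound 4 (0.17 log units; within the scatter).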

Compound 4, half-maximal effective concentration: 704 nM
Compound 4: middle estimate off by 13-fold (1.11 log units), on the low side; measured number above the stated range.
By their numbers in this assay, from the lowest: compound 2; then compounds 1 and 4 (each within the scatter of the next); then compound 3.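

Sulfamoyl and the group that enters match in heavy-atom count and in counted donors and acceptors, yet this assay shows a large change, a 19-fold higher number from compound 2 to compound 4 (1.28 log units; beyond the scatter). This position, para to a large group, therefore responds strongly to the exchange even though those counts stay the same.

Nothing at hand tells why this exchange has so large an effect. On these data alone, it also remains open whether a methylsulfonyl group or a carboxylic acid in this place would give a number close to that of compound 2 or close to that of compound 4.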